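Working notes on compound 1 and the step to compound 4

The compounds below may be only part of what the source reports. "The series", "measured", "known", "first", "only" and "open" are said of these compounds alone.

Measured compounds:
- compound 1 `COc1ccc(OCCCCCN2CCCC(COC(=O)c3ccccc3N3C(=O)CC(C)C3=O)C2)cc1` gives 14500 nM in an in vitro functional assay on HEK ts201 cells for antagonist activity at Neuronal acetylcholine receptor; alpha4/beta2 (Homo sapiens), read by fluorescence and calcium flux; a higher number here means a weaker inhibitor, a lower number a stronger inhibitor
- compound 2 `O=C(OCC1CCCNC1)c1ccccc1-c1ccccc1` gives 7080 nM in this assay
- compound 3 `O=C(NCC1CCCN(CCCc2ccccc2)C1)c1ccccc1-c1ccccc1` gives 20000 nM in this assay

On these three numbers compound 1 stands second highest. Its nearest neighbour is compound 3, whose number is higher by an amount within the scatter, so the two cannot be told apart. Compound 2 sits at a lower number, and that gap lies beyond the scatter. Among the compounds with values here, none of these pairs differs in one place, so no single step is drawn between them.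

Compound 4 `COc1cccc(OCCCCCN2CCCC(COC(=O)c3ccccc3N3C(=O)CC(C)C3=O)C2)c1OC` differs from compound 1 in one place: 2,3-dimethoxyphenyl in place of 4-methoxyphenyl on an oxygen on a saturated carbon. Within the data shown here, no measured pair shows this change, so nothing here says in which direction it moves this assay. Without such a precedent, the step is expected to fall within the scatter, with no clear direction, which is what the estimated step of a 1.1-fold lower number from compound 1 to compound 4 (0.05 log units; within the scatter) means. Compound 4 is therefore estimated at 13000 nM, with a range from 5000 nM to 35000 nM, pending measurement.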

Compound 4, half-maximal inhibitory concentration: 8710 nM
For compound 4 the middle estimate is 1.5-fold (0.17 log units) above the measured one; measured number inside the range.
By their numbers in this assay, from the lowest: compounds 2, 4, 1 and 3 (each within the scatter of the next, the first and the last beyond it).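

In this assay, within the data shown here, the first step at this position, a 1.7-fold lower number from compound 1 to compound 4 (0.22 log units; within the scatter), stays within the scatter, so 4-methoxyphenyl and 2,3-dimethoxyphenyl on an oxygen on a saturated carbon cannot be told apart here. This one exchange alters the number of methoxy groups and their placement on the phenyl ring together, and the reading is not resolved from that of compound 1 for the combined change. Nothing available bears on why the step is this small.

Among these compounds, whether 2-methoxyphenyl or 3-methoxyphenyl alone would read apart from 2,3-dimethoxyphenyl remains open, as the single step does not separate the two changes. Also open, going by these compounds, is whether an unsubstituted phenyl, or a phenyl carrying an amine or a carboxylic acid, at this place would give a step beyond the scatter.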